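Moving two fluorines on the amide-type nitrogen's phenyl

The compounds below may be only part of what the source reports. "The series", "measured", "known", "first", "only" and "open" are said of these compounds alone.

Measured so far in a functional assay on A549 cells (Homo sapiens) for cytotoxicity, read by MTT assay, with a stated time of 72 h (a lower number here means a stronger inhibitor, a higher number a weaker inhibitor), are three compounds:
- compound 1 `O=C(CN1CCN(c2nnc(Cc3ccccc3)c3ccccc23)CC1)Nc1c(F)cccc1F` at 84500 nM
- compound 2 `O=C(CN1CCN(c2nnc(Cc3ccncc3)c3ccccc23)CC1)Nc1cccc(Br)c1` at 1530 nM
- compound 3 `O=C(CN1CCN(c2nnc(Cc3ccncc3)c3ccccc23)CC1)Nc1cccc(F)c1` at 4600 nM

Compound 1 has the highest of these three numbers. Compound 4 `O=C(CN1CCN(c2nnc(Cc3ccccc3)c3ccccc23)CC1)Nc1ccc(F)c(F)c1` differs from compound 1 by 3,4-difluorophenyl in place of 2,6-difluorophenyl on an amide-type nitrogen in one place, with 3,4-difluorophenyl in place of 2,6-difluorophenyl on an amide-type nitrogen. Among the compounds with values here, only one measured step bears on this, a 3.0-fold higher number from compound 2 to compound 3 (0.48 log units; beyond the scatter) for fluoro in place of bromo on an aromatic carbon, and it is modest. Compound 3 stands far lower at 4600 nM but differs from compound 1 in more than one place, so only part of that gap is expected to carry over. A lower number is expected (estimated a 5.6-fold lower number from compound 1 to compound 4 (0.75 log units; beyond the scatter)). Compound 4 is estimated at 15000 nM (expected range 3500 nM to 60000 nM).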

Compound 4, half-maximal inhibitory concentration: 10100 nM
The estimate for compound 4 lay 1.5-fold (0.17 log units) above the measured number, within the range that was stated.
By their numbers in this assay, from the lowest: compound 2; then compound 3; then compound 4; then compound 1.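

In this assay, 3,4-difluorophenyl in place of 2,6-difluorophenyl on the amide-type nitrogen gives an 8.4-fold lower number from compound 1 to compound 4 (0.92 log units; beyond the scatter) and so shows that this site responds to a rearrangement of the same atoms, with the shared core unchanged. The earlier step exchanged one halogen for another, whereas here both groups carry the same two fluorines. Nothing measured here explains the difference. Open, on these data alone, is whether a methoxy group or an amine on this phenyl would lower the number further, and whether the same change would hold on the core of compound 2.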